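The source may hold more compounds than are shown below. What is called first, only, known or untested is meant among the compounds shown, and "the series" means these compounds.

Compound 1, `OC[C@H]1O[C@@H](n2cnc3c(SCc4ccccc4Cl)ncnc32)[C@H](O)[C@@H]1O`, gives 117 nM in an assay on isolated protein for inhibition of Equilibrative nucleoside transporter 1 (Homo sapiens); a lower number here means a stronger inhibitor, a higher number a weaker inhibitor.
Compound 2, `N#Cc1ccccc1CSc1ncnc2c1ncn2[C@@H]1O[C@H](CO)[C@@H](O)[C@H]1O`, gives 38.9 nM.
Compound 3, `O=[N+]([O-])c1ccccc1CSc1ncnc2c1ncn2[C@@H]1O[C@H](CO)[C@@H](O)[C@H]1O`, gives 115 nM.

Among these three, compound 1 sits at the top end of the numbers: it is level with compound 3, the step of a 1.0-fold lower number from compound 1 to compound 3 (0.01 log units; within the scatter) staying within the scatter, while compound 2 lies further off, with a 3.0-fold lower number from compound 1 to compound 2 (0.48 log units; beyond the scatter).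

Compound 4, `OC[C@H]1O[C@@H](n2cnc3c(SCc4ccc(Cl)c(Cl)c4)ncnc32)[C@H](O)[C@@H]1O`, is the next structure to follow from compound 1. The change is 3,4-dichlorophenyl in place of 2-chlorophenyl on a saturated chain carbon bound to a sulfur. The measured steps all exchange one group for another at the same spot on the ring, as in a 3.0-fold lower number from compound 1 to compound 2 (0.48 log units; beyond the scatter) and a 3.0-fold higher number from compound 2 to compound 3 (0.47 log units; beyond the scatter); none of them adds a second chlorine or places chlorine as in 3,4-dichlorophenyl, so they bear only loosely on this step. With chloro already present in compound 1 and its number close to that of compound 3, the expectation is a step no larger than modest, in either direction. The estimate for compound 4 is 85 nM, with a range from 25 nM to 300 nM. That estimate amounts to an expected step of a 1.4-fold lower number from compound 1 to compound 4 (0.14 log units; within the scatter).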

Compound 4, inhibition constant: 12.6 nM
Beside the measured number, compound 4's estimate is 6.7-fold (0.83 log units) above it; the whole stated range lies above it.
By their numbers in this assay, from the lowest: compound 4; then compound 2; then compounds 3 and 1 (each within the scatter of the next).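

In this assay, 3,4-dichlorophenyl in place of 2-chlorophenyl gives a 9.3-fold lower number from compound 1 to compound 4 (0.97 log units; beyond the scatter), a larger step than any seen among the earlier exchanges of chloro, cyano and nitro. The same comparison with the other two compounds gives a 9.1-fold lower number from compound 3 to compound 4 (0.96 log units; beyond the scatter) and a 3.1-fold lower number from compound 2 to compound 4 (0.49 log units; beyond the scatter), so compound 4 has the lowest number of the four, and this position can move the number further than those earlier exchanges showed. Nothing given here explains the size of this step.

Going by these compounds, compound 4 differs from compound 1 both in its added chlorine and in where chlorine sits, so the share of each in this step remains open. Also open, on these data alone, is how an amine, a carboxylic acid or a methoxy group on this ring would compare.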